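Sulfoximine for Fluorinated Carbinol on the Shared Core

The source may hold more compounds than are shown below. What is called first, only, known or untested is meant among the compounds shown, and "the series" means these compounds.

Compound 1 `CC#C[C@H]1CN(S(=O)(=O)c2ccc(N)nc2)CCN1c1ccc(C(O)(CC#N)C(F)(F)F)cc1` — 219 nM
Compound 2 `CC#C[C@H]1CN(S(=O)(=O)c2ccc(N)nc2)CCN1c1ccc(C(O)(C(F)(F)F)C(F)(F)F)cn1` — 421 nM
Compound 3 `CC#C[C@H]1CN(S(=O)(=O)c2ccc(N)nc2)CCN1c1ccc(S(=O)(=O)NC)cn1` — 381 nM

In an assay on cells (Hepatocyte) for inhibition of glucokinase regulatory protein (Mus musculus), with stated times of 20 min and 40 min (a higher number here means that more compound is needed for the effect, a lower number that less compound is needed), compound 1 gives 219 nM, the lowest of the three numbers, though its gaps to compound 3 and compound 2 both fall within the scatter. Compound 4 `CC#C[C@H]1CN(S(=O)(=O)c2ccc(N)nc2)CCN1c1ccc(S(=N)(=O)C2CC2)cc1` differs from compound 1 in one place: a group of 6 heavy atoms (3 carbon, 1 nitrogen, 1 oxygen, 1 sulfur; one three-membered non-aromatic ring of carbon only) in place of a group of 9 heavy atoms (4 carbon, 1 nitrogen, 1 oxygen, 3 fluorine; no ring), on an aromatic carbon. Within the data shown here, one measured step bears on it, a 1.1-fold lower number from compound 2 to compound 3 (0.04 log units; within the scatter), in which a sulfur-bearing group likewise replaced a fluorinated carbinol on an aromatic carbon and the number hardly moved. A comparable outcome is therefore expected here, a step of a 1.1-fold higher number from compound 1 to compound 4 (0.06 log units; within the scatter), not beyond the scatter. Compound 4 is estimated at 250 nM, with a range from 100 nM to 650 nM.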

Compound 4, half-maximal effective concentration: 208 nM
Compound 4: the middle estimate sits 1.2-fold (0.08 log units) above what was measured, within the range that was stated.
By their numbers in this assay, from the lowest: compounds 4, 1, 3 and 2 (each within the scatter of the next, the first and the last beyond it).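

The step of a 1.1-fold lower number from compound 1 to compound 4 (0.02 log units; within the scatter) in this assay shows that this position, on an aromatic carbon para to a large group, tolerates a sulfoximine carrying a three-membered carbon ring in place of the fluorinated carbinol, with the number staying within the scatter. The entering group has fewer heavy atoms and no fluorine, so fluorine is not required at this position for a number in this range. On these data alone, whether an amine or a carboxylic acid here would leave the number equally unmoved remains open. Nothing given here explains why the number holds.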